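The compounds below may be only part of what the source reports. "The series", "measured", "known", "first", "only" and "open" are said of these compounds alone.

In a functional assay on U-937 cells (Homo sapiens) for antiproliferative activity, read by CCK-8 assay, with a stated time of 72 h (on this read-out lower numbers stand for stronger inhibition and higher numbers for weaker inhibition), compound 1 `Cc1cc(Nc2cc(N3CCN(C)CC3)nc(Nc3ccc(Cl)cc3)n2)n[nH]1` gives 55.4 nM while compound 2 `Cc1cc(Nc2cc(N3CCN(C)CC3)nc(Nc3cccc(Cl)c3)n2)n[nH]1` gives 21.7 nM and so holds the lower of the two numbers. Compound 3 `Cc1cc(Nc2cc(N3CCN(C)CC3)nc(Nc3ccc(C#N)cc3)n2)n[nH]1` has not yet been measured. Its difference from compound 2 is 4-cyanophenyl in place of 3-chlorophenyl on a nitrogen on an aromatic ring in short 4-cyanophenyl in place of 3-chlorophenyl on a nitrogen on an aromatic ring. Going by the values given here, one measured step bears on this, namely a 2.6-fold lower number from compound 1 to compound 2 (0.41 log units; beyond the scatter) with 3-chlorophenyl in place of 4-chlorophenyl, a modest move. Among the compounds with values here, no measured compound carries a nitrile, so that step is only a loose guide. The 4-cyanophenyl group is taken here as closer to the 4-chlorophenyl of compound 1 at 55.4 nM than to 3-chlorophenyl, so a modest rise of similar size is expected. In this assay the expected change is a 2.8-fold higher number from compound 2 to compound 3 (0.44 log units; beyond the scatter) on this reading. Compound 3 is estimated at 60 nM with an expected range from 20 nM to 180 nM for repeated measurements.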

Compound 3, half-maximal inhibitory concentration: 9.03 nM
Estimate against measurement, compound 3: 6.6-fold (0.82 log units) above; measured number below the stated range.
By their numbers in this assay, from the lowest: compound 3; then compound 2; then compound 1.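

In this assay, a phenyl ring carrying a nitrile on this nitrogen gives a 2.4-fold lower number from compound 2 to compound 3 (0.38 log units; beyond the scatter) and so holds the lowest of the three numbers, which shows that this position is not limited to a chlorophenyl group. With the ring position unchanged, cyano in place of chloro gives a 6.1-fold lower number from compound 1 to compound 3 (0.79 log units; beyond the scatter) and reverses what the two chlorophenyl compounds alone suggested, since a 4-substituted ring now gives a lower number than the 3-chlorophenyl of compound 2. Nothing available on the compounds explains why the nitrile gives this result.

The compounds shown leave open whether 3-cyanophenyl would give a still lower number than 4-cyanophenyl or would lose ground, as the chlorine pair cannot answer that. They also leave open how a carboxylic acid, a primary amide or a methoxy group would behave at the 4-position of this ring.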